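The source may report more compounds than this note shows. Statements on the series, on what has been measured and on what is new or still open speak of the compounds shown alone.

Measured compounds:
- compound 1 `O=c1[nH]nc2n(c1=O)CCN2c1ccc(Cl)cc1` — 1%
- compound 2 `N=c1c(=O)[nH]nc2n1CCN2c1ccc(Cl)cc1` — 27%

In a functional assay on T47D cells (Homo sapiens) for cytotoxicity, with a stated time of 72 h, tested at 50 ug/mL (on this read-out lower numbers stand for a weaker effect and higher numbers for a stronger effect at the one concentration tested), compound 1 gives 1% and compound 2 gives 27%. Compound 2 stands highest of the two numbers; its nearest neighbour, compound 1, lies lower by a gap beyond the usual scatter. Within the data shown here, no pair of measured compounds differs in a single place, so no measured step is available to guide the next change.

Compound 3 `N=c1c(=O)[nH]nc2n1CCN2c1ccccc1` differs from compound 2 in one place: hydrogen in place of chloro on an aromatic carbon. Among the measured compounds shown here, nothing measured so far shows what removing the chloro does in this assay. The expectation for the step from compound 2 to compound 3 is a small loss, possibly none beyond the scatter: a number 9 percentage points lower from compound 2 to compound 3 (within the scatter). Compound 3 is therefore estimated at 18% in this assay, within a range from 2% to 38%.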

Compound 3, a percentage reported as inhibition, at one concentration (the size of the read-out at that concentration, not a potency): 3%
Estimate against measurement, compound 3: 15 percentage points above; measured number inside the range.
By their numbers in this assay, from the lowest: compounds 1 and 3 (each within the scatter of the next); then compound 2.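

In this assay, hydrogen in place of chloro on an aromatic carbon, para to a large group, gives a number 24 percentage points lower from compound 2 to compound 3 (beyond the scatter). Among these compounds, this is the first single-place change that can be read, and it shows that the read-out on the core of compound 2 is sensitive to the group at this position, with the chloro-bearing compound 2 giving the higher number of the pair. No measurement available on the series explains this step.

On these data alone, whether a different group at this position, such as fluoro, methoxy or an amine, would keep, raise or lower the number remains open. Also open, as far as these compounds go, is whether the same change would have a comparable effect on the core of compound 1, and whether moving the chloro elsewhere on the aromatic ring would preserve the effect seen for compound 2.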